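A Pyrazole Attachment Isomer Awaits Its Number

The compounds below may be only part of what the source reports. "The series", "measured", "known", "first", "only" and "open" are said of these compounds alone.

In a functional assay on A2780 cells (Homo sapiens) for inhibition (a lower number here means a stronger inhibitor, a higher number a weaker inhibitor), compound 1 (`CCNCc1cc(-c2c(C(=O)NCC)noc2-c2cc(C(C)C)c(O)cc2O)on1`) gives 45 nM and compound 2 (`CCNC(=O)c1noc(-c2cc(C(C)C)c(O)cc2O)c1-c1cc(CNC(C)C)no1`) gives 38 nM while compound 3 (`CCNC(=O)c1noc(-c2cc(C(C)C)c(O)cc2O)c1-c1ccn(C(C)C)n1`) gives 45 nM and so stands level with compound 1 and within the scatter of compound 2. Compound 4 (`CCNC(=O)c1noc(-c2cc(C(C)C)c(O)cc2O)c1-c1cnn(C(C)C)c1`) has 1-isopropyl-1H-pyrazol-4-yl in place of 1-isopropyl-1H-pyrazol-3-yl on an aromatic carbon. Among the measured compounds shown here, no measured pair tests this attachment directly. The nearest evidence is the exchange of a whole group at that place, and both such steps stay within the scatter: no change at the digits printed from compound 1 to compound 3 (within the scatter) and a 1.2-fold higher number from compound 2 to compound 3 (0.07 log units; within the scatter) are the sizes seen. No step beyond the scatter is therefore expected in this assay and the estimated step is a 1.1-fold lower number from compound 3 to compound 4 (0.05 log units; within the scatter) in size. Compound 4 is estimated at 40 nM with a range of 15 nM to 110 nM expected.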

Compound 4, half-maximal inhibitory concentration: 21 nM
For compound 4 the middle estimate is 1.9-fold (0.28 log units) above the measured one, and the stated range covers the measured number.
By their numbers in this assay, from the lowest: compounds 4, 2, 1 and 3 (each within the scatter of the next, the first and the last beyond it).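

In this assay, among the compounds shown here, moving only the attachment point of the pyrazole gives a 2.1-fold lower number from compound 3 to compound 4 (0.33 log units; beyond the scatter), the first step in this set to pass beyond the scatter, so at this position the attachment alone can shift the number. Against the isoxazole-type groups, the 1-isopropyl-1H-pyrazol-4-yl group gives a 2.1-fold lower number from compound 1 to compound 4 (0.33 log units; beyond the scatter) but a 1.8-fold lower number from compound 2 to compound 4 (0.26 log units; within the scatter), so its edge holds over only one of them. Nothing measured here accounts for the difference between the two attachments. Going by these compounds, it remains open whether a methyl or a cyclopropyl in place of the isopropyl of 1-isopropyl-1H-pyrazol-4-yl would keep this number.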